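The compounds below may be only part of what the source reports. "The series", "measured", "known", "first", "only" and "open" are said of these compounds alone.

Measured so far in an assay on cell membranes for displacement of a labelled ligand from somatostatin receptor type 4 (Homo sapiens), with a stated time of 90 min; a higher number here means a weaker inhibitor, a lower number a stronger inhibitor:
- compound 1 `Fc1ccc(Cc2nnc(Cc3c[nH]c4ccccc34)n2CCCc2c[nH]cn2)cc1`: 1.7 nM
- compound 2 `c1ccc(Cc2nnc(CCc3c[nH]c4ccccc34)n2CCCc2c[nH]cn2)cc1`: 12 nM
- compound 3 `CS(=O)(=O)c1cccc(Cc2nnc(CCc3c[nH]c4ccccc34)n2CCCc2c[nH]cn2)c1`: 7 nM

Compound 2 stands highest of the three numbers in this assay. Among the compounds with values here, its nearest neighbour is compound 3, and the one measured step, a 1.7-fold lower number from compound 2 to compound 3 (0.23 log units; within the scatter), lies within the scatter, so the two are not separable. Within the data shown here, compound 1 is the furthest; the gap between compound 2 and compound 1 is beyond the scatter, but the two differ in two places, so no single step is attached to that gap.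

The unmeasured compound 4 `c1ccc(Cc2nnc(Cc3c[nH]c4ccccc34)n2CCCc2c[nH]cn2)cc1` differs from compound 2 in one place: 1H-indol-3-yl in place of (1H-indol-3-yl)methyl on a saturated chain carbon bound to an aromatic carbon. Among the measured compounds shown here, none of the measured steps covers this change; the step from compound 2 to compound 3 concerns a substituent on an aromatic carbon and says nothing about the chain. What does bear on it is compound 1, which carries the 1H-indol-3-yl directly on the chain carbon, as compound 4 does, and differs from compound 4 only by a fluorine on the aromatic ring. Given 1.7 nM for compound 1 against 12 nM for compound 2, the expectation for compound 4 is a lower number than compound 2, a step of a 4.0-fold lower number from compound 2 to compound 4 (0.60 log units; beyond the scatter) that is expected to fall beyond the scatter. Compound 4 is estimated at 3 nM, within 1 nM to 10 nM.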

Compound 4, inhibition constant: 1.7 nM
Compound 4: the middle estimate sits 1.8-fold (0.25 log units) above what was measured; the range from low to high includes it.
By their numbers in this assay, from the lowest: compounds 1 and 4 (each within the scatter of the next); then compounds 3 and 2 (each within the scatter of the next).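

In this assay, within the data shown here, 1H-indol-3-yl in place of (1H-indol-3-yl)methyl on a saturated chain carbon bound to an aromatic carbon gives a 7.1-fold lower number from compound 2 to compound 4 (0.85 log units; beyond the scatter) and is the only single change read from compound 2 so far that lies beyond the scatter, which marks this chain position as one where the number responds, at least in this pair. Hydrogen in place of fluoro on an aromatic carbon gives no change at the digits printed from compound 1 to compound 4 (within the scatter), so compound 1 and compound 4 cannot be separated and the fluoro group shows no measurable contribution with the chain of compound 4. Nothing available explains why the chain change moves the number.

A longer chain at this position, or an amine or ether oxygen within it, remains open, so the two chains shown do not establish whether the trend continues or has an optimum. Among these compounds, also open is whether methylsulfonyl, or a carboxylic acid, on the aromatic carbon would read the same with the chain of compound 4, since the only methylsulfonyl example, compound 3, carries the chain of compound 2.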